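The source may hold more compounds than are shown below. What is called first, only, known or untested is meant among the compounds shown, and "the series" means these compounds.

Of the compounds shown here, three of a shared core have been measured in a functional assay on MCF7 cells (Homo sapiens) for inhibition, read by MTT assay, with a stated time of 72 h; on this read-out lower numbers stand for stronger inhibition and higher numbers for weaker inhibition. Compound 1, with the structure `CC(C)(C)OC(=O)N1CCN(C(=S)SCc2cn(-c3ccccc3F)nn2)CC1`, gives 89600 nM in this assay. Compound 2, with the structure `Cc1cc(=O)oc2cc(OCCn3cc(CSC(=S)N4CCN(C(=O)OC(C)(C)C)CC4)nn3)ccc12`, gives 90400 nM, a number that sits so close to that of compound 1 that the two cannot be told apart; the two numbers are the highest of the three, meaning the weakest inhibition seen here. Compound 3, with the structure `O=C(OCc1ccccc1)N1CCN(C(=S)SCc2cn(Cc3ccccc3F)nn2)CC1`, gives 7950 nM, a clearly lower number and so clearly stronger inhibition than compound 1, but compound 3 differs from compound 1 in two places at once, so the gain cannot be tied to one of them.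

The next compound to consider is compound 4, with the structure `CC(C)(C)OC(=O)N1CCN(C(=S)SCc2cn(Cc3ccccc3Cl)nn2)CC1`, which differs from compound 1 in one place: 2-chlorobenzyl in place of 2-fluorophenyl on an aromatic nitrogen. Among the compounds with values here, no single-change step of this kind has been measured, so the expected size rests on the gap between compound 1 and compound 3 alone. A lower number, and so stronger inhibition, is expected for compound 4, with an estimated step from compound 1 of a 2.6-fold lower number from compound 1 to compound 4 (0.41 log units; beyond the scatter). In this assay compound 4 is estimated to give 35000 nM, with a range from 8000 nM to 95000 nM.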

Compound 4, half-maximal inhibitory concentration: 6090 nM
For compound 4 the middle estimate is 5.7-fold (0.76 log units) above the measured one, and the stated range ends above it.
By their numbers in this assay, from the lowest: compounds 4 and 3 (each within the scatter of the next); then compounds 1 and 2 (each within the scatter of the next).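

In this assay, replacing 2-fluorophenyl with 2-chlorobenzyl on the aromatic nitrogen of the five-membered ring gives a 15-fold lower number from compound 1 to compound 4 (1.17 log units; beyond the scatter), a large step toward stronger inhibition. Within the data shown here, this is the first change that can be tied to one place, and it shows that this nitrogen substituent alone can move the read-out strongly while the rest of the core of compound 1 stays the same. Nothing measured here gives a reason for the gain.

The swap still bundles two differences, since chlorine replaces fluorine and a benzyl group replaces a phenyl group, so the step cannot be divided between them; 2-chlorophenyl or 2-fluorobenzyl on the core of compound 1 would be needed to separate the two. As far as these compounds go, it also remains open how far the trend extends at this nitrogen, for example to a longer chain such as 2-phenylethyl or to a group carrying an amine.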